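This account rests on a few compounds, and the source may have more. Where it says the series, first, only, none or still open, it means among the compounds named here.

Within the data shown here, compound 3 `CC1CCCCC1NC(=O)[C@H]1OC(n2cnc3c(N)ncnc32)[C@H](O)[C@@H]1O` holds the highest of the numbers measured so far: in an assay on cell membranes for binding affinity to 2-oxoglutarate receptor 1 (Rattus norvegicus), read by radioligand binding (on this read-out higher numbers stand for weaker inhibition and lower numbers for stronger inhibition), compound 3 gives 69.5 nM. Compound 1 `CCCCCCCCCNC(=O)[C@H]1OC(n2cnc3c(N)ncnc32)[C@H](O)[C@@H]1O` gives 31 nM, and compound 2 `CC(=O)NCCNC(=O)[C@H]1OC(n2cnc3c(N)ncnc32)[C@H](O)[C@@H]1O` gives 46 nM. The step of a 2.2-fold higher number from compound 1 to compound 3 (0.35 log units; beyond the scatter) lies beyond the scatter, whereas the step of a 1.5-fold higher number from compound 2 to compound 3 (0.18 log units; within the scatter) does not. Compound 4 `CC(C)CONC(=O)[C@H]1OC(n2cnc3c(N)ncnc32)[C@H](O)[C@@H]1O` differs from compound 3 in one place: isobutoxy in place of 2-methylcyclohexyl on an amide-type nitrogen. The two measured steps that exchanged the group on this amide-type nitrogen, a 2.2-fold higher number from compound 1 to compound 3 (0.35 log units; beyond the scatter) and a 1.5-fold higher number from compound 2 to compound 3 (0.18 log units; within the scatter), were both small, so only a small step is expected here as well, in either direction or none beyond the scatter. Compound 4 is therefore estimated at 80 nM, with a likely range from 30 nM to 250 nM. That estimate would be expected to mean a step of a 1.2-fold higher number from compound 3 to compound 4 (0.06 log units; within the scatter).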

Compound 4, inhibition constant: 20 nM
Beside the measured number, compound 4's estimate is 4.0-fold (0.60 log units) above it; the whole stated range lies above it.
By their numbers in this assay, from the lowest: compounds 4, 1, 2 and 3 (each within the scatter of the next, the first and the last beyond it).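

On this amide-type nitrogen, isobutoxy is the only group shown that joins through an oxygen, and in this assay replacing the ring-bearing 2-methylcyclohexyl with it gives a clear move to a lower number (a 3.5-fold lower number from compound 3 to compound 4 (0.54 log units; beyond the scatter)). The same exchange for 2-acetamidoethyl also goes lower (a 2.3-fold lower number from compound 2 to compound 4 (0.36 log units; beyond the scatter)), while the exchange for nonyl leaves no difference that can be told from the scatter (a 1.6-fold lower number from compound 1 to compound 4 (0.19 log units; within the scatter)). The compounds shown do not separate the effect of the oxygen from that of the branched chain, which a plain isobutyl group on this nitrogen would address. Nothing measured here explains these differences.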